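Replacing 3,5-dimethylpiperazin-1-yl with 2,6-dimethylmorpholin-4-yl

The source may hold more compounds than are shown below. What is called first, only, known or untested is meant among the compounds shown, and "the series" means these compounds.

- compound 1 `C[C@@H]1CN(C(=O)c2ccnc(Nc3nc4cnc(Nc5ccc(F)c(C(F)(F)F)c5)cc4[nH]3)c2)C[C@H](C)O1`: 30000 nM
- compound 2 `O=C(c1ccnc(Nc2nc3cnc(Nc4ccc(F)c(F)c4)cc3[nH]2)c1)N1CCN(C2CC2)CC1`: > 50000 nM (a limit)
- compound 3 `C[C@@H]1CN(C(=O)c2ccnc(Nc3nc4cnc(Nc5ccc(F)c(F)c5)cc4[nH]3)c2)C[C@H](C)N1`: > 50000 nM (a limit)

In an ADME assay on CHO cells (Cricetulus griseus) for cytotoxicity, read by MTT assay (on this read-out higher numbers stand for lower toxicity in this test and lower numbers for higher toxicity in this test), compound 3 gives > 50000 nM, which is a limit of the assay and not a number. This places it at the limit of > 50000 nM in this assay, at which 2 of the 3 values shown sit.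

Compound 4 `C[C@@H]1CN(C(=O)c2ccnc(Nc3nc4cnc(Nc5ccc(F)c(F)c5)cc4[nH]3)c2)C[C@H](C)O1` is compound 3 with one change on a carbonyl carbon: 2,6-dimethylmorpholin-4-yl in place of 3,5-dimethylpiperazin-1-yl on a carbonyl carbon.

Within the data shown here, the only measured step between closely matched compounds is a step that the two limits leave unreadable from compound 2 to compound 3, so it offers no size to carry over. Compound 1 also carries 2,6-dimethylmorpholin-4-yl, although it differs elsewhere, and compound 1 gives a true number, 30000 nM. On that single value, a modest step towards lower numbers is expected, though its size stays uncertain and compound 4 could also reach the limit. The estimated step is expected to be an at least 1.2-fold lower number from compound 3 to compound 4 (0.09 log units; that floor lies within the scatter). For compound 4 the estimate is 40000 nM, with an expected range from 20000 nM to 80000 nM.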

Compound 4, half-maximal cytotoxic concentration: > 50000 nM
Compound 4: only a limit was reported; the forecaster's own chance of this, stated with the estimate: 45%; at least 1.2-fold (0.09 log units) between middle value and limit.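

In this assay, the swap on the carbonyl carbon leaves compound 4 at a limit of the assay and not a number, as compound 3 also is, so the steps among compound 2, compound 3 and compound 4 cannot be read. Among these compounds, the one readable step is an at least 1.6-fold higher number from compound 1 to compound 4 (0.22 log units; that floor lies within the scatter), with fluoro in place of trifluoromethyl on an aromatic carbon, so 2,6-dimethylmorpholin-4-yl is now seen with both groups, but that floor does not firmly separate the two compounds. The morpholine group thus joins both piperazine groups at the same limit when the aromatic fluoro is kept: the limit of > 50000 nM in this assay, at which 3 of the 4 values shown sit.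

From the compounds shown here alone, how far these three groups differ beyond the limit stays open. Also open, going by these compounds, is how a simple piperidine, or a carboxylic acid on that ring, would read in this assay.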